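A few compounds are considered here, and "the series" means these few. Any claim that something is new, unique, unknown or untested is made for them only; others in the source may bear on it.

Compound 1 `CC(C)N(Cc1cccc(OCCCCCC(=O)O)c1)C(=O)c1ccccc1` in an ADME assay on HEK293 cells (Homo sapiens) for cytotoxicity, read by CellTiter-Glo and resazurin assay, with a stated time of 72 h (on this read-out higher numbers stand for an effect only at larger amounts of compound and lower numbers for an effect already at smaller amounts), reaches only the assay limit of > 26000 nM.
Compound 2 `CC(C)N(Cc1cccc(OCCCCCC(=O)O)c1)C(=O)c1ccc(-c2cccc(OC(F)(F)F)c2)cc1` in this assay likewise stops at a limit, > 26000 nM.
Compound 3 `CCOC(=O)CCCCCOc1cccc(CN(C(=O)c2ccccc2)C(C)C)c1` in this assay also gives no number but a limit, > 26000 nM.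

Compound 3 thus stands where the other two stand, at the limit that all three values share (the limit of > 26000 nM in this assay, at which 3 of the 3 values shown sit). Compound 4 `CCOC(=O)CCCCCOc1cccc(CN(C(=O)c2ccc(-c3cccc(C(C)=O)c3)cc2)C(C)C)c1` carries one change against compound 3: 3-acetylphenyl in place of hydrogen on an aromatic carbon. Two measured steps resemble it in that a group replaces a hydrogen, yet both are unreadable, both ends sitting at the limit of > 26000 nM in this assay, at which 3 of the 3 values shown sit: a step that the two limits leave unreadable from compound 1 to compound 2 and a step that the two limits leave unreadable from compound 1 to compound 3. The first of them also places an aryl group on an aromatic carbon and shows no readable effect. In this assay compound 4 is therefore expected to stay at or beyond the limit. The expected step, a step that the limit leaves unreadable from compound 3 to compound 4, is essentially none beyond the scatter. Compound 4 is estimated at 30000 nM, between 15000 nM and 100000 nM.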

Compound 4, half-maximal effective concentration: > 26000 nM
Compound 4 gave a limit, no number (the forecaster's own chance of this, stated with the estimate: 80%); the middle value does not contradict the limit.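

No new step can be read between compound 3 and compound 4, because both stop at a limit rather than a number: the limit of > 26000 nM in this assay, at which 4 of the 4 values shown sit.

The compounds shown leave open at what concentration any of them would take effect in this assay.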